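A few compounds are considered here, and "the series" means these few. Any claim that something is new, unique, unknown or untested is made for them only; others in the source may bear on it.

In a functional assay on MCF7 cells (Homo sapiens) for antiproliferative activity, read by sulforhodamine B assay, with a stated time of 48 h (a higher number here means a weaker inhibitor, a lower number a stronger inhibitor), compound 3 `COc1ccc(OC)c(/C=C/C(=O)C(=Cc2ccc(O)c(OC)c2)C(=O)/C=C/c2cc(OC)ccc2OC)c1` gives 400 nM. That value lies within the usual scatter of both compound 2 `COc1ccc(C=C(C(=O)/C=C/c2cccc(OC)c2OC)C(=O)/C=C/c2cccc(OC)c2OC)cc1O`, at 310 nM, and compound 1 `COc1cc(OC)c(C=C(C(=O)/C=C/c2cccc(OC)c2OC)C(=O)/C=C/c2cccc(OC)c2OC)c(OC)c1`, at 720 nM. Compound 4 `COc1ccc(OC)c(/C=C/C(=O)C(=Cc2ccc(O)c(F)c2)C(=O)/C=C/c2cc(OC)ccc2OC)c1` differs from compound 3 by one small edit, fluoro in place of methoxy on an aromatic carbon, ortho to a hydroxy group, so that 4-hydroxy-3-methoxyphenyl becomes 3-fluoro-4-hydroxyphenyl.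

Within the data shown here, only one measured step offers any guidance, and it is indirect. That step, a 2.3-fold lower number from compound 1 to compound 2 (0.37 log units; beyond the scatter), is modest and also changes the group on the double-bonded chain carbon, but it replaces 2,4,6-trimethoxyphenyl and involves no fluoro group. Among the measured compounds shown here, no measured pair exchanges methoxy for fluoro, so the size and direction of this change remain open. No shift beyond the scatter is therefore expected, and the estimated step is a 1.1-fold higher number from compound 3 to compound 4 (0.05 log units; within the scatter). For compound 4 the expected value is 450 nM, within an estimated range from 180 nM to 1100 nM.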

Compound 4, half-maximal inhibitory concentration: 460 nM
The estimate for compound 4 lay 1.0-fold (0.01 log units) below the measured number; measured number inside the range.
By their numbers in this assay, from the lowest: compounds 2, 3, 4 and 1 (each within the scatter of the next, the first and the last beyond it).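

In this assay, exchanging methoxy for fluoro on this ring gives a 1.2-fold higher number from compound 3 to compound 4 (0.06 log units; within the scatter), so the 3-fluoro-4-hydroxyphenyl and 4-hydroxy-3-methoxyphenyl compounds cannot be told apart in this test. At this position, ortho to a hydroxy group, a group of 1 heavy atom with no hydrogen-bond acceptor can therefore stand in for a group of 2 heavy atoms with 1 hydrogen-bond acceptor, without a shift beyond the scatter. No measurement at hand offers an explanation for this result.

Among these compounds, only this one exchange can be read at this position, so it remains open whether an amine or a chloro group there would move the number beyond the scatter. As far as these compounds go, whether methoxy and fluoro would still match on a ring without the hydroxy group is also open.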